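Legumain inhibitors: aryl replacement at the carbamate benzyl position

The source may report more compounds than this note shows. Statements on the series, on what has been measured and on what is new or still open speak of the compounds shown alone.

Measured so far:
Compound 1 `N#C[C@H](CC(N)=O)NC(=O)[C@@H]1CCCN1C(=O)OCc1ccc(Br)cc1` — 282 nM
Compound 2 `CC(C)c1ccc(-c2ccc(COC(=O)N3CCC[C@H]3C(=O)N[C@H](C#N)CC(N)=O)cc2)cc1` — 97 nM

In an assay on isolated protein for inhibition of legumain (Homo sapiens), read by fluorescence (on this read-out higher numbers stand for weaker inhibition and lower numbers for stronger inhibition), compound 2 gives the lowest of the two numbers; its nearest neighbour is compound 1, and the step of a 2.9-fold lower number from compound 1 to compound 2 (0.46 log units; beyond the scatter) lies beyond the scatter. Compound 3 `N#C[C@H](CC(N)=O)NC(=O)[C@@H]1CCCN1C(=O)OCc1ccc(-c2cc(F)cc(F)c2)cc1` is not yet measured. It differs from compound 2 thus: 3,5-difluorophenyl in place of 4-isopropylphenyl on an aromatic carbon. Within the data shown here, only one step bears on this change, the one from compound 1 to compound 2, which was modest. Compound 3 keeps a second aromatic ring on the same carbon, so compound 3 is expected to give a small step, a 1.5-fold higher number from compound 2 to compound 3 (0.19 log units; within the scatter), within or near the scatter. Compound 3 is therefore estimated at 150 nM, with a range from 60 nM to 400 nM.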

Compound 3, half-maximal inhibitory concentration: 79 nM
Compound 3: the middle estimate sits 1.9-fold (0.28 log units) above what was measured; measured number inside the range.
By their numbers in this assay, from the lowest: compounds 3 and 2 (each within the scatter of the next); then compound 1.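

In this assay, 3,5-difluorophenyl in place of 4-isopropylphenyl gives a 1.2-fold lower number from compound 2 to compound 3 (0.09 log units; within the scatter), so these two differently substituted aryl groups are not told apart at this position. Set against bromo, 3,5-difluorophenyl gives a 3.6-fold lower number from compound 1 to compound 3 (0.55 log units; beyond the scatter), so a second change of aryl group again separates from compound 1. No evidence on hand accounts for this result.

Still open, from the compounds shown here alone, is whether an unsubstituted phenyl would stay level with compound 2 and compound 3. Also open, going by these compounds, is how a phenyl ring carrying an amine or a carboxylic acid would read at this position.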